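From alkyne to aryl on a shared core

The source may hold more compounds than are shown below. What is called first, only, known or untested is meant among the compounds shown, and "the series" means these compounds.

Values measured in a functional assay on CAPAN-1 cells (Homo sapiens) for antiproliferative activity, with a stated time of 72 h (on this read-out higher numbers stand for weaker inhibition and lower numbers for stronger inhibition), are these:

- compound 1 `CCCCC#Cc1cc([C@@H]2O[C@H](CO)[C@@H](O)[C@H]2O)n2ncnc(N)c12` gives 1000 nM
- compound 2 `Nc1ncnn2c([C@@H]3O[C@H](CO)[C@@H](O)[C@H]3O)cc(C#CC3CC3)c12` gives 20 nM
- compound 3 `Nc1ncnn2c([C@@H]3O[C@H](CO)[C@@H](O)[C@H]3O)cc(-c3ccc(F)cc3F)c12` gives 50900 nM

Compound 2 has the lowest number of the three, and both of its steps to the others lie beyond the scatter. Compound 4 `COc1ccc(-c2cc([C@@H]3O[C@H](CO)[C@@H](O)[C@H]3O)n3ncnc(N)c23)cc1` has not yet been measured in this assay and differs from compound 2 by one change: 4-methoxyphenyl in place of 2-cyclopropylethynyl on an aromatic carbon. Among the compounds with values here, the closest precedent is the large 2500-fold higher number from compound 2 to compound 3 (3.41 log units; beyond the scatter) when 2,4-difluorophenyl enters at the same place. The large 51-fold higher number from compound 1 to compound 3 (1.71 log units; beyond the scatter) runs the same way, so both measured swaps of an alkyne for an aryl group raised the number. However, compound 3 is the only aryl example, so the effect of the methoxy group remains unknown. Within the data shown here, a large rise is therefore expected, perhaps somewhat smaller than the one seen for compound 3. The expected change is a 750-fold higher number from compound 2 to compound 4 (2.88 log units; beyond the scatter) by this estimate. For compound 4 the estimated value in this assay is 15000 nM with a range from 2000 nM to 80000 nM expected.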

Compound 4, half-maximal inhibitory concentration: 43900 nM
Estimate against measurement, compound 4: 2.9-fold (0.47 log units) below; measured number inside the range.
By their numbers in this assay, from the lowest: compound 2; then compound 1; then compounds 4 and 3 (each within the scatter of the next).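

With 4-methoxyphenyl, a second aryl group at this position shows the same direction as 2,4-difluorophenyl: there is a 2200-fold higher number from compound 2 to compound 4 (3.34 log units; beyond the scatter) and also a 44-fold higher number from compound 1 to compound 4 (1.64 log units; beyond the scatter) in the piece's second alkyne comparison, so the rise on leaving an alkyne no longer rests on compound 3 alone. The two aryl groups cannot be told apart, with a 1.2-fold lower number from compound 3 to compound 4 (0.06 log units; within the scatter) separating them, and so replacing both fluorines with one methoxy group at a different place on the phenyl ring leaves no readable mark on this read-out. No measurement is available that accounts for the distance between the aryl and alkyne compounds.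

On these data alone, it remains open whether a phenyl ring joined through a triple bond would retain the low number of compound 2 at 20 nM or follow the aryl compounds. Also open, as far as these compounds go, is how a pyridine ring, an amine or a cyclohexyl group would behave at this position.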